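Chromene series: cyano for fluoro on the pendant aryl

The compounds below may be only part of what the source reports. "The series", "measured", "known", "first", "only" and "open" are said of these compounds alone.

Measured so far:
- compound 1, `CC1=C(c2ccc(O)cc2)C(c2ccc(OC[C@H](C)N3CC[C@@H](C)C3)cc2)Oc2cc(O)ccc21`: 0.2 nM
- compound 2, `CC1=C(c2cccc(F)c2)C(c2ccc(OC[C@H](C)N3CC[C@@H](C)C3)cc2)Oc2ccc(O)cc21`: 1 nM
- compound 3, `CC1=C(c2cccc(O)c2)C(c2ccc(OC[C@@H](C)N3CCCC3)cc2)Oc2ccc(O)cc21`: 0.2 nM

In a functional assay on MCF7 cells (Homo sapiens) for antiproliferative activity, read by CellTiter-Glo, with a stated time of 5 days (a lower number here means a stronger inhibitor, a higher number a weaker inhibitor), compound 2 gives the highest of the three numbers. Both compound 1 and compound 3 give numbers lower by a margin beyond the usual scatter, so compound 2 is the weakest inhibitor of the set as it stands.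

Compound 4, `CC1=C(c2ccc(C#N)cc2)C(c2ccc(OC[C@H](C)N3CC[C@@H](C)C3)cc2)Oc2ccc(O)cc21`, is not yet measured. It differs from compound 2 in one place: 4-cyanophenyl in place of 3-fluorophenyl on a double-bonded ring carbon

Among the compounds with values here, no pair of measured compounds isolates this change, so there is nothing to anchor its size. Within the data shown here, the pendant aryl in compound 2 already lacks a hydroxyl, as does the one in compound 4, and compound 2 still gives a low number. The expected step from compound 2 to compound 4 is therefore no change at the digits printed from compound 2 to compound 4 (within the scatter), none beyond the scatter. For compound 4 the estimate in this assay is 1 nM, with a range from 0.3 nM to 4 nM.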

Compound 4, half-maximal inhibitory concentration: 10 nM
Compound 4: the middle estimate sits 10-fold (1.00 log units) below what was measured, outside the stated range (above it).
By their numbers in this assay, from the lowest: compounds 1 and 3 (each within the scatter of the next); then compound 2; then compound 4.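

On a double-bonded ring carbon of the shared core, 4-cyanophenyl in place of 3-fluorophenyl gives a 10-fold higher number from compound 2 to compound 4 (1.00 log units; beyond the scatter) in this assay, so this position tells hydroxyl-free aryl groups apart. The low number of compound 2 therefore does not carry over to every aryl group without a hydroxyl. Nothing measured here bears on the reason for this step.

Still open, as far as these compounds go, is whether the nitrile itself or its place on the ring sets the step. 3-Cyanophenyl and 4-fluorophenyl on the same core would separate the two.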